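Swapping methoxy groups for hydroxyls on the hydrazone arm

A few compounds are considered here, and "the series" means these few. Any claim that something is new, unique, unknown or untested is made for them only; others in the source may bear on it.

For the measured compounds named here, compound 2 `COc1ccc(/C=N/NC(=O)Nc2ccc(Oc3ccnc(-c4nncn4CCN(C)C)c3)c(F)c2)c(OC)c1OC` gives the only real number here: in a functional assay on U-87MG ATCC cells (Homo sapiens) for cytotoxicity, read by MTT assay, with a stated time of 72 h (on this read-out higher numbers stand for weaker inhibition and lower numbers for stronger inhibition), compound 2 gives 7650 nM. Compound 1 `CN(C)CCn1cnnc1-c1cc(Oc2ccc(NC(=O)N/N=C/c3ccc(O)c(F)c3)cc2F)ccn1` reaches only a limit, (the limit of > 100000 nM in this assay, at which 1 of the 2 values shown sits), so in this assay compound 1 gives > 100000 nM. Compound 3 `CN(C)CCn1cnnc1-c1cc(Oc2ccc(NC(=O)N/N=C/c3ccc(O)cc3O)cc2F)ccn1` differs from compound 2 by 2,4-dihydroxyphenyl in place of 2,3,4-trimethoxyphenyl on a carbon with a double bond to nitrogen. Going by the values given here, the one measured step, an at least 13-fold lower number from compound 1 to compound 2 (1.11 log units; beyond the scatter), shows that a phenyl carrying hydroxyl rather than methoxy groups sits at the limit. Compound 3 returns to hydroxyls, so a rise of roughly that size is expected, a 7.8-fold higher number from compound 2 to compound 3 (0.89 log units; beyond the scatter). Compound 3 is therefore estimated at 60000 nM, between 15000 nM and 200000 nM.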

Compound 3, half-maximal inhibitory concentration: 15400 nM
The estimate for compound 3 lay 3.9-fold (0.59 log units) above the measured number; the measured number falls inside the stated range.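

Hydroxyls on the phenyl do not by themselves bring the weak result. In this assay the change gives a 2.0-fold higher number from compound 2 to compound 3 (0.30 log units; within the scatter) so 2,4-dihydroxyphenyl and 2,3,4-trimethoxyphenyl cannot be told apart on this carbon with a double bond to nitrogen. Against 3-fluoro-4-hydroxyphenyl the same group gives an at least 6.4-fold lower number from compound 1 to compound 3 (0.81 log units; beyond the scatter) and so only compound 1 stands apart, with a figure that is a limit rather than a number: the limit of > 100000 nM in this assay, at which 1 of the 3 values shown sits.

Still open, on these data alone, is how this position would respond to a phenyl carrying an amine or a carboxylic acid. As far as these compounds go, whether the fluorine or the placing of the hydroxyls sets compound 1 apart also stays open, since its group differs from the others in both.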